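The compounds below may be only part of what the source reports. "The series", "measured", "known", "first", "only" and "open" are said of these compounds alone.

Measured in an ADME assay on MCF-10A cells (Homo sapiens) for inhibition, read by MTT assay, with a stated time of 48 h, tested at 2 uM; a lower number here means less inhibition, a higher number more inhibition at the concentration tested (going by the name of the read-out):

compound 1 `Cc1noc(C)c1-c1ccc2c(c1)C(c1ccccc1)N(Cc1nnc(-c3ccccc3)o1)C(=O)N2C` gives 12.4%
compound 2 `Cc1noc(C)c1-c1ccc2c(c1)C(c1ccccc1)N(Cc1ncc(-c3ccccc3)o1)C(=O)N2C` gives 3.7%
compound 3 `Cc1nc(-c2ccccc2)sc1CN1C(=O)N(C)c2ccc(-c3c(C)noc3C)cc2C1c1ccccc1` gives 4.9%

Compound 3 sits second highest of the three numbers. Its nearest neighbour is compound 2, with a number 1.2 percentage points higher from compound 2 to compound 3 (within the scatter); its furthest is compound 1, with a number 7.5 percentage points lower from compound 1 to compound 3 (within the scatter). The remaining measured step, a number 8.7 percentage points lower from compound 1 to compound 2 (within the scatter), is likewise within the scatter, so the three heteroaryl groups on the saturated chain carbon bound to the amide-type nitrogen in the ring cannot be told apart on these data.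

Compound 4 `Cc1nc(-c2ccc(F)cc2)sc1CN1C(=O)N(C)c2ccc(-c3c(C)noc3C)cc2C1c1ccccc1` differs from compound 3 by fluoro in place of hydrogen on an aromatic carbon, the same change read one bond further out being phenyl to 4-fluorophenyl. Among the compounds with values here, no measured step touches this phenyl ring; the only steps available exchange whole heteroaryl groups, and each of those stayed within the scatter. A single fluoro for hydrogen is a smaller change than any of them, so no step beyond the scatter is expected in this assay, and the expected step is a number 0.6 percentage points higher from compound 3 to compound 4 (within the scatter). Compound 4 is therefore estimated at 5.5%, with a range from 0% to 14%.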

Compound 4, a percentage reported as inhibition, at one concentration (the size of the read-out at that concentration, not a potency): 6.5%
Compound 4: the middle estimate sits 1 percentage points below what was measured, within the range that was stated.
By their numbers in this assay, from the lowest: compounds 2, 3, 4 and 1 (each within the scatter of the next).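

Within the data shown here, compound 4 gives the first reading of a change on the outer phenyl ring rather than an exchange of the whole heteroaryl group. In this assay, among these compounds, phenyl to 4-fluorophenyl gives a number 1.6 percentage points higher from compound 3 to compound 4 (within the scatter), so fluoro on this aromatic carbon, para to a large group, produces no step that can be told from the scatter. No measurement on hand offers an explanation for this result.

Going by these compounds, a single fluoro says little about this position as a whole, so it remains open whether a methoxy group, an amine or a carboxylic acid at the same place would give a step beyond the scatter. On these data alone, it also remains open whether 4-fluorophenyl would behave the same way on the 1,3,4-oxadiazole of compound 1 or the 1,3-oxazole of compound 2.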